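What Removing One Methoxy Group May Do

The source may report more compounds than this note shows. Statements on the series, on what has been measured and on what is new or still open speak of the compounds shown alone.

In a functional assay on MM1.S cells (Homo sapiens) for inhibition, with a stated time of 72 h (a higher number here means a weaker inhibitor, a lower number a stronger inhibitor), compound 1 (`O=C(NO)c1ccc(CN(C2CC2)S(=O)(=O)c2cc(F)c(F)c(F)c2F)cc1`) gives 480 nM and compound 2 (`CC(C)CN(Cc1ccc(C(=O)NO)cc1)S(=O)(=O)c1cc(F)c(F)c(F)c1F`) gives 690 nM as its reading. Compound 3 (`COc1cc(C(=O)NO)ccc1CN(C(C)C)S(=O)(=O)c1cc(F)c(F)c(F)c1F`) gives 5750 nM in the same test, the highest of the three numbers and so the weakest inhibitor of the three. Compound 4 (`CC(C)N(Cc1ccc(C(=O)NO)cc1)S(=O)(=O)c1cc(F)c(F)c(F)c1F`) has not yet been measured. It differs from compound 3 by one change, hydrogen in place of methoxy on an aromatic carbon. Among the measured compounds shown here, the only measured single-place step lies elsewhere: isobutyl in place of cyclopropyl on a sulfonamide nitrogen gives a 1.4-fold higher number from compound 1 to compound 2 (0.16 log units; within the scatter) and says nothing directly about the methoxy. Compounds 1 and 2 do carry hydrogen on that aromatic carbon, as compound 4 does. Compound 3 differs from each of them in two places, however, so its gap to them cannot be assigned to the methoxy alone. Even so, compound 4 is expected to read near compound 1 at 480 nM and compound 2 at 690 nM rather than near compound 3. The expected step is an 11-fold lower number from compound 3 to compound 4 (1.04 log units; beyond the scatter) and would lie beyond the scatter. Compound 4 is estimated at 520 nM in this assay with a range from 200 nM to 1400 nM expected to hold the measurement.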

Compound 4, half-maximal inhibitory concentration: 1380 nM
Compound 4: middle estimate off by 2.7-fold (0.42 log units), on the low side, within the range that was stated.
By their numbers in this assay, from the lowest: compounds 1, 2 and 4 (each within the scatter of the next, the first and the last beyond it); then compound 3.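

In this assay, among the compounds shown here, the step of a 4.2-fold lower number from compound 3 to compound 4 (0.62 log units; beyond the scatter) is the first to isolate this aromatic carbon: with isopropyl on the sulfonamide nitrogen in both compounds, hydrogen in place of methoxy gives a lower number, a modest change beyond the scatter, which the earlier compounds could not show because compound 3 differed from each of them in two places. Compound 4 also places isopropyl among the groups on the sulfonamide nitrogen, with a 2.0-fold higher number from compound 2 to compound 4 (0.30 log units; within the scatter) lying within the scatter and a 2.9-fold higher number from compound 1 to compound 4 (0.46 log units; beyond the scatter) lying beyond it, so this series separates isopropyl from cyclopropyl but not from isobutyl. Nothing at hand explains why the methoxy step has this size.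

From the compounds shown here alone, the methoxy step rests on one pair with isopropyl on the nitrogen, so it remains open whether it would have the same size with cyclopropyl or isobutyl there. Going by these compounds, it is also open whether a methyl group, a fluorine atom or a hydroxyl group on that aromatic carbon, meta to the hydroxycarbamoyl group, would read nearer to hydrogen or to methoxy.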